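Working notes: methyl for fluoro, compound 2 to compound 3

The source may report more compounds than this note shows. Statements on the series, on what has been measured and on what is new or still open speak of the compounds shown alone.

compound 1 `NC(=O)N/N=C/c1ccc(Oc2ccc(F)cc2Cl)cc1`: > 68 mg/kg
compound 2 `NC(=O)N/N=C/c1ccc(Sc2ccc(F)cc2)cc1`: > 120 mg/kg

In a functional assay on the whole organism with Mus musculus as the target, with a stated time of 1 h (on this read-out lower numbers stand for an effect already at smaller amounts and higher numbers for an effect only at larger amounts of compound), compound 1 gives only a limit, > 68 mg/kg. In this assay compound 2 likewise gives only a limit, > 120 mg/kg. Both values shown are thus limits (the limit of > 120 mg/kg in this assay, at which 1 of the 2 values shown sits, and (the limit of > 68 mg/kg in this assay, at which 1 of the 2 values shown sits)), and compound 2 stands at one of them; no number separates the two compounds. Compound 3 `Cc1ccc(Sc2ccc(/C=N/NC(N)=O)cc2)cc1` differs from compound 2 by methyl in place of fluoro on an aromatic carbon. Among the compounds with values here, no measured step exists to lean on, so no change beyond the scatter is expected; the estimated step is a step that the limit leaves unreadable from compound 2 to compound 3, near none. Compound 3 is expected at 150 mg/kg (60 mg/kg to 400 mg/kg), most probably reported again as a limit.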

Compound 3, dose for half-maximal effect: > 300 mg/kg
Compound 3: a limit, no number; the forecaster's own chance of this, stated with the estimate: 75%; middle value at least 2.0-fold (0.30 log units) away from the limit.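

Compound 2 and compound 3 both give only limits in this assay, and the step between them cannot be read. Still open, as far as these compounds go, is whether methyl in place of fluoro changes the dose for half-maximal effect at all, and what number compound 1, compound 2 or compound 3 would reach.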